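A Second Bromo Group Enters the Shared Core

A few compounds are considered here, and "the series" means these few. Any claim that something is new, unique, unknown or untested is made for them only; others in the source may bear on it.

Measured compounds:
compound 1 `OCc1cc(Br)c(O)c(O)c1Br`: 21400 nM
compound 2 `CCCOCc1cc(O)c(O)c(Br)c1`: "not determined" (no result reported)

Two compounds have been taken into the study so far. Compound 1 `OCc1cc(Br)c(O)c(O)c1Br` carries two bromo groups and a hydroxymethyl group on its core; in a functional assay on HCT-116 cells (Homo sapiens) for cytotoxicity, read by MTT assay, with a stated time of 96 h (a lower number here means a stronger inhibitor, a higher number a weaker inhibitor), compound 1 gives 21400 nM, a weak result. Among the compounds with values here, compound 2 `CCCOCc1cc(O)c(O)c(Br)c1` has a single bromo group and a propoxymethyl group; in this assay compound 2 gives "not determined" (no result reported), so it stands nowhere on the numbers and no step can be drawn from it.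

The next compound, compound 3 `CCCOCc1cc(Br)c(O)c(O)c1Br`, arises from compound 2 by one change: bromo in place of hydrogen on an aromatic carbon. The change gives compound 3 the same pair of bromo groups that compound 1 carries, with the propoxymethyl group kept.

Within the data shown here, no step between measured compounds exists here, so the size of the change cannot be read from the data. The only anchor is the weak value of compound 1. In this assay the expectation is a modest step, if any, not clearly beyond the scatter, in either direction. Compound 3 is estimated at 15000 nM, within 5000 nM to 45000 nM.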

Compound 3, half-maximal inhibitory concentration: 800 nM
Compound 3: middle estimate off by 19-fold (1.27 log units), on the high side, outside the stated range (below it).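

With both bromo groups held in place, the oxygen on the saturated carbon proves to matter: in this assay putting propyl in place of its hydrogen brings a 27-fold lower number from compound 1 to compound 3 (1.43 log units; beyond the scatter) and this step lies beyond the usual scatter. The hydroxymethyl group of compound 1 and the propoxymethyl group of compound 3 therefore cannot be treated as interchangeable in this assay, and the weak result of compound 1 does not speak for every compound with this pair of bromo groups. The step from compound 2 to compound 3 cannot be read, as compound 2 has no number, so the effect of the added bromo group stays unknown, and no supporting measurement explains the change on the oxygen.

On this oxygen the compounds shown carry only hydrogen and propyl, so it remains open how a methyl group, a longer chain such as hexyl, or a chain ending in an amine or a carboxylic acid would compare. They also leave open whether the propoxymethyl group would give a comparable result with a single bromo group on the core.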